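From Ethoxycarbonyl to Benzoyl, Starting from a Limit

The source may hold more compounds than are shown below. What is called first, only, known or untested is meant among the compounds shown, and "the series" means these compounds.

In an ADME assay on HEK293 cells (Homo sapiens) for cytotoxicity, with a stated time of 72 h (a lower number here means that less compound is needed, a higher number that more compound is needed for the effect), none of the three measured compounds yields a number. Compound 1 `C=C[C@@](C)(/C=C/c1ccc(O)cc1)CC/C=C(C)/C=C/C(=O)OCC` gives > 36600 nM as a limit. Compound 2 `C=C[C@@](C)(/C=C/c1ccc(O)c(/C=C/C(=O)OCC)c1)CCC=C(C)C` gives > 36600 nM as a limit. Compound 3 `CCOC(=O)/C=C/c1cc(/C=C/[C@](C)(/C=C/c2ccc(OC)cc2)CCC=C(C)C)ccc1O` gives > 36600 nM as a limit as well, so it has no readable position in the series. The whole record so far is the limit of > 36600 nM in this assay, at which 3 of the 3 values shown sit, and nothing more.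

Compound 4 `COc1ccc(/C=C/[C@@](C)(/C=C/c2ccc(O)c(/C=C/C(=O)c3ccccc3)c2)CCC=C(C)C)cc1` departs from compound 3 in one place, described by phenyl in place of ethoxy on a carbonyl carbon and amounting to phenyl in place of ethoxy on a carbonyl carbon, so that 2-(ethoxycarbonyl)ethenyl becomes 2-benzoylethenyl. Within the data shown here, the only measured step is a step that the two limits leave unreadable from compound 2 to compound 3 and it concerns a different change, 2-(4-methoxyphenyl)ethenyl in place of vinyl, so it offers no size to carry over. Among the measured compounds shown here, no measured step touches the carbonyl substituent, which leaves the size and direction of this change poorly constrained. Compound 4 is therefore expected to stay close to the limit reached by the others, with a modest move towards lower concentrations as the only shift allowed for. The expected change is an at least 1.2-fold lower number from compound 3 to compound 4 (0.08 log units; that floor lies within the scatter) in this assay and carries wide uncertainty. For compound 4 the estimated value is 30000 nM with an expected range from 10000 nM to 60000 nM in this assay.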

Compound 4, half-maximal effective concentration: > 36600 nM
Compound 4: no number, only a limit; the forecaster's own chance of this, stated with the estimate: 60%; at least 1.2-fold (0.08 log units) between middle value and limit.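

In this assay compound 3 and compound 4 both stand only as limits, so no step can be read for the change from ethoxycarbonyl to benzoyl. The record now reads: the limit of > 36600 nM in this assay, at which 4 of the 4 values shown sit. The compounds shown leave open what concentration, if any, produces the effect for any of them, and whether this change alters it.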